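Can an indolyl group restore activity to compound 3?

The source may report more compounds than this note shows. Statements on the series, on what has been measured and on what is new or still open speak of the compounds shown alone.

Measured in a functional assay on DU-145 cells (Homo sapiens) for inhibition, read by trypan blue exclusion, with a stated time of 72 h; on this read-out lower numbers stand for stronger inhibition and higher numbers for weaker inhibition:
- compound 1 `Cn1c(=O)c(S(=O)(=O)c2ccc(F)cc2F)cc2cnc(Nc3cccc4[nH]ccc34)nc21`: 750 nM
- compound 2 `Cn1c(=O)c(S(=O)(=O)c2ccc(F)cc2F)cc2cnc(Nc3ccc4c(c3)CC(=O)N4)nc21`: 100000 nM
- compound 3 `Cn1c(=O)c(S(=O)(=O)c2ccc(F)cc2F)cc2cnc(Nc3ccccn3)nc21`: 75000 nM

Two of these three numbers lie together at the high end, a 1.3-fold lower number from compound 2 to compound 3 (0.12 log units; within the scatter), a gap within the scatter. Compound 3 is one of that pair, and the remaining number is far lower: a 100-fold higher number from compound 1 to compound 3 (2.00 log units; beyond the scatter).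

The next structure is compound 4 `Cc1cc2cc(Nc3ncc4cc(S(=O)(=O)c5ccc(F)cc5F)c(=O)n(C)c4n3)ccc2[nH]1`, which differs from compound 3 as follows: 2-methyl-1H-indol-5-yl in place of pyridin-2-yl on a nitrogen on an aromatic ring. In words, 2-methyl-1H-indol-5-yl stands in place of pyridin-2-yl on a nitrogen on an aromatic ring.

Among the compounds with values here, no measured compound carries this exact group. The nearest comparison is compound 1, whose 1H-indol-4-yl group goes with 750 nM. A larger group does not guarantee a low number, however, as compound 2 shows: a 130-fold higher number from compound 1 to compound 2 (2.12 log units; beyond the scatter). A move to a lower number in this assay is therefore expected, though probably a smaller move than the full gap to compound 1. The estimated step is a 19-fold lower number from compound 3 to compound 4 (1.27 log units; beyond the scatter). For compound 4 the expected value is 4000 nM, with an estimated range of 500 nM to 40000 nM.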

Compound 4, half-maximal inhibitory concentration: 750 nM
Beside the measured number, compound 4's estimate is 5.3-fold (0.73 log units) above it; the range from low to high includes it.
By their numbers in this assay, from the lowest: compounds 1 and 4 (each within the scatter of the next); then compounds 3 and 2 (each within the scatter of the next).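

In this assay the result shows a 100-fold lower number from compound 3 to compound 4 (2.00 log units; beyond the scatter), so a second indolyl group, attached differently and carrying a methyl, also goes with a low number at this nitrogen. The two indolyl groups cannot be told apart on this read-out, with no change at the digits printed from compound 1 to compound 4 (within the scatter). Size alone does not account for the result: both groups in the next step hold 10 heavy atoms, yet there is a 130-fold lower number from compound 2 to compound 4 (2.12 log units; beyond the scatter), with a five-membered aromatic ring in place of a five-membered non-aromatic ring.

Nothing available here explains why the indolyl groups go with the low numbers. Still open, from the compounds shown here alone, is whether the methyl matters on its own, and whether an indole carrying an amine or a carboxylic acid would keep a number this low.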